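Cytotoxicity on HeLa Cells Across Four Ether-Linked Analogues

The compounds below may be only part of what the source reports. "The series", "measured", "known", "first", "only" and "open" are said of these compounds alone.

Measured compounds in an ADME assay on HeLa cells (Homo sapiens) for cytotoxicity, read by MTT assay; on this read-out lower numbers stand for stronger inhibition and higher numbers for weaker inhibition:
Compound 1, `COc1ccc(C[C@H]2COC(=O)[C@@H]2Cc2ccc(OCc3cn(Cc4ccc(Cl)cc4)nn3)c(OC)c2)cc1OC`: 242000 nM
Compound 2, `COc1ccc(C[C@H]2COC(=O)[C@@H]2Cc2ccc(OCC(=O)Nc3ccc(C)cc3)c(OC)c2)cc1OC`: 228000 nM
Compound 3, `COc1ccc(C[C@H]2COC(=O)[C@@H]2Cc2ccc(OCC(=O)N3CCCCC3)c(OC)c2)cc1OC`: 293000 nM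

Compound 3 has the highest of the three numbers, but its gaps to compound 1 and to compound 2 are both within the scatter, so the three compounds cannot be ranked. Compound 4, `COc1ccc(C[C@H]2COC(=O)[C@@H]2Cc2ccc(OCc3cn(-c4cccc(Cl)c4)nn3)c(OC)c2)cc1OC`, has not yet been measured. The change from compound 3 is 1-(3-chlorophenyl)-1H-1,2,3-triazol-4-yl in place of (piperidin-1-yl)carbonyl on a saturated chain carbon bound to an oxygen on an aromatic ring. Among the measured compounds shown here, the one measured step at this place, a 1.3-fold higher number from compound 2 to compound 3 (0.11 log units; within the scatter), stayed within the scatter. For the measured compounds named here, no measured step introduces a triazole ring; compound 1 simply carries one and gives 242000 nM in this assay. Compound 4 is therefore expected to give 250000 nM, between 120000 nM and 520000 nM. The expected step of a 1.2-fold lower number from compound 3 to compound 4 (0.07 log units; within the scatter) is thus estimated to lie within the scatter.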

Compound 4, half-maximal inhibitory concentration: 493000 nM
Compound 4: middle estimate off by 2.0-fold (0.29 log units), on the low side, and the stated range covers the measured number.
By their numbers in this assay, from the lowest: compounds 2, 1, 3 and 4 (each within the scatter of the next, the first and the last beyond it).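

In this assay the triazole group in place of the (piperidin-1-yl)carbonyl stays within the scatter (a 1.7-fold higher number from compound 3 to compound 4 (0.23 log units; within the scatter)), whereas in place of the (4-methylphenyl)carbamoyl it gives a modest step beyond the scatter (a 2.2-fold higher number from compound 2 to compound 4 (0.33 log units; beyond the scatter)). With the triazole kept, 3-chlorophenyl in place of 4-chlorobenzyl on an aromatic nitrogen also gives a modest step beyond the scatter (a 2.0-fold higher number from compound 1 to compound 4 (0.31 log units; beyond the scatter)), so the group on that nitrogen can move the number. Nothing available explains these steps.

That last change alters both the chlorine's ring position and the carbon link to the triazole. A 4-chlorophenyl or 3-chlorobenzyl group on that nitrogen would separate the two.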